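Trifluoromethyl to 4-ethyl-1,3-oxazol-2-yl on the shared core

The source may hold more compounds than are shown below. What is called first, only, known or untested is meant among the compounds shown, and "the series" means these compounds.

In a physicochemical assay for lipophilicity, measured as octanol-water partition, at pH 7.4 (a lower number here means a more polar compound, a higher number a more lipophilic compound), compound 2 `Cc1ccc(Cn2c(=O)[nH]c3c(N)nc(C(F)(F)F)cc32)cn1` gives 2.3. Compound 3 `Cc1cc(Cn2c(=O)[nH]c3c(N)nc(C(F)(F)F)cc32)no1` gives 2.1, and the step of a number 0.20 log units lower from compound 2 to compound 3 (within the scatter) separates it from compound 2 by no real margin. Compound 1 `Cc1ccc(Cn2c(=O)[nH]c3c(N)nc(-c4ncco4)cc32)cn1` gives 1.6, clearly lower.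

The change to compound 4 `CCc1coc(-c2cc3c([nH]c(=O)n3Cc3ccc(C)nc3)c(N)n2)n1` is 4-ethyl-1,3-oxazol-2-yl in place of trifluoromethyl on an aromatic carbon. The step that bears on it is the modest a number 0.70 log units higher from compound 1 to compound 2 (beyond the scatter), which runs the opposite way and has no ethyl group. The other step concerns a different place. For the measured compounds named here, no measured step isolates the ethyl group, so its offsetting contribution is assumed. The expected net change is small, a number 0.10 log units higher from compound 2 to compound 4 (within the scatter), and not beyond the scatter. For compound 4 the estimated value is 2.4, with an expected range of 2 to 2.9.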

Compound 4, distribution coefficient: 3.2
Estimate against measurement, compound 4: 0.80 log units below, outside the stated range (above it).
By their numbers in this assay, from the lowest: compound 1; then compounds 3 and 2 (each within the scatter of the next); then compound 4.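

In this assay, 4-ethyl-1,3-oxazol-2-yl in place of trifluoromethyl gives a number 0.90 log units higher from compound 2 to compound 4 (beyond the scatter), which reverses the order seen at this aromatic carbon with the 1,3-oxazol-2-yl of compound 1. Ethyl in place of hydrogen on the oxazole gives a number 1.60 log units higher from compound 1 to compound 4 (beyond the scatter), a large step that outruns a number 0.70 log units higher from compound 1 to compound 2 (beyond the scatter). Nothing measured here accounts for the size of this step.

The compounds shown leave open whether a methyl group or a propyl chain in place of the ethyl would give a step of similar size, and whether the ethyl step would carry over with the 5-methyl-1,2-oxazol-3-yl of compound 3.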